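Turning an Amide Back into a Urea

The source may report more compounds than this note shows. Statements on the series, on what has been measured and on what is new or still open speak of the compounds shown alone.

Of the compounds shown here, three built on one shared core have been tested in a functional assay on MDA-MB-435 cells (Homo sapiens) for inhibition, read by sulforhodamine B assay, with a stated time of 48 h; on this read-out higher numbers stand for lower toxicity in this test and lower numbers for higher toxicity in this test. Compound 1 `COc1cc(-c2nn(-c3cccc(NC(=O)Nc4ccc(Cl)c(Cl)c4)c3)cc2-c2ccncc2)ccc1Cl` gives only a limit there, > 50000 nM, so no number is known for it (the limit of > 50000 nM in this assay, at which 1 of the 3 values shown sits). Compound 2 `COc1cc(-c2nn(-c3cccc(NC(=O)Nc4cccc(C(F)(F)F)c4)c3)cc2-c2ccncc2)ccc1Cl` gives 8070 nM in this assay. Compound 3 `COc1cc(-c2nn(-c3cccc(NC(=O)c4ccc(Cl)c(C(F)(F)F)c4)c3)cc2-c2ccncc2)ccc1Cl` gives 24700 nM in this assay, the highest of the two numbers. Exchanging the 3,4-dichlorophenyl for 3-(trifluoromethyl)phenyl on the amide-type nitrogen gave an at least 6.1-fold lower number from compound 1 to compound 2 (0.79 log units; beyond the scatter). Exchanging the (3-(trifluoromethyl)phenyl)amino on the carbonyl carbon for 4-chloro-3-(trifluoromethyl)phenyl, which turns a urea into an amide, gave a 3.1-fold higher number from compound 2 to compound 3 (0.49 log units; beyond the scatter). Compound 4 `COc1cc(-c2nn(-c3cccc(NC(=O)Nc4ccc(Cl)c(C(F)(F)F)c4)c3)cc2-c2ccncc2)ccc1Cl` undoes a change of that kind: (4-chloro-3-(trifluoromethyl)phenyl)amino in place of 4-chloro-3-(trifluoromethyl)phenyl on a carbonyl carbon. The step from compound 2 to compound 3, run backwards, is the closest guide, so compound 4 is expected to show a 3.1-fold lower number from compound 3 to compound 4 (0.49 log units; beyond the scatter). Compound 1 is also a urea and reached only a limit, which leaves the outcome uncertain. The expected value for compound 4 in this assay is 8000 nM, within a range from 2000 nM to 40000 nM.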

Compound 4, concentration lethal to 50% of the cells: > 32500 nM
Compound 4: a limit, no number; the forecaster's own chance of this, stated with the estimate: 20%; middle value at least 4.0-fold (0.60 log units) from the limit.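

Compound 4 gives only a limit, not a number: the limit of > 32500 nM in this assay, at which 1 of the 4 values shown sits. Placing chloro where compound 2 carries hydrogen on its aromatic ring gave an at least 4.0-fold higher number from compound 2 to compound 4 (0.60 log units; beyond the scatter), so on this urea that single atom is enough to move the read-out towards lower toxicity in this test. Turning the amide back into a urea gave an at least 1.3-fold higher number from compound 3 to compound 4 (0.11 log units; that floor lies within the scatter), so this change did not bring the low number of compound 2 back, and the urea and amide with the same 4-chloro-3-(trifluoromethyl)phenyl group cannot be told apart by size of step.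

Compound 1 and compound 4 are both limits, and the step between them cannot be read, which leaves the effect of trifluoromethyl in place of chloro open. Going by these compounds, how a nitrile or an amine in place of that chloro would read in this assay also stays open.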